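A Trifluoromethyl Group Replaces Bromo on the Benzyl

A few compounds are considered here, and "the series" means these few. Any claim that something is new, unique, unknown or untested is made for them only; others in the source may bear on it.

Compound 1 `COc1cc(OC)c(-c2coc3cc(OCc4ccccc4)ccc3c2=O)cc1OC` and compound 2 `COc1cc(OC)c(-c2coc3cc(OCc4ccc(Br)cc4)ccc3c2=O)cc1OC` share one core and differ by a single bromo. In a functional assay on HepG2 cells (Homo sapiens) for antiproliferative activity, read by MTT assay, with a stated time of 24 h (on this read-out higher numbers stand for weaker inhibition and lower numbers for stronger inhibition), compound 1 gives 1320 nM and compound 2 gives 1050 nM. Within the data shown here, these two numbers cannot be told apart: the one measured step, a 1.3-fold lower number from compound 1 to compound 2 (0.10 log units; within the scatter), stays within the usual scatter, so compound 2 stands level with its only neighbour.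

Compound 3 `COc1cc(OC)c(-c2coc3cc(OCc4ccccc4C(F)(F)F)ccc3c2=O)cc1OC` has not yet been measured. Its difference from compound 2 is 2-(trifluoromethyl)phenyl in place of 4-bromophenyl on a saturated chain carbon bound to an oxygen on an aromatic ring. In other words, 4-bromobenzyl gives way to 2-(trifluoromethyl)benzyl. Among the measured compounds shown here, no measured compound carries a trifluoromethyl group, so the bromo step is the only guide, and it is an indirect one. With that single small step to go on, and compound 2 at 1050 nM as the starting point, no shift beyond the scatter is expected in either direction. The expected change is a 1.1-fold higher number from compound 2 to compound 3 (0.06 log units; within the scatter), which is a small one. For compound 3 the estimated value in this assay is 1200 nM, with an expected range from 550 nM to 2600 nM.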

Compound 3, half-maximal inhibitory concentration: 6550 nM
Compound 3: middle estimate off by 5.5-fold (0.74 log units), on the low side; measured number outside the range, above it.
By their numbers in this assay, from the lowest: compounds 2 and 1 (each within the scatter of the next); then compound 3.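

This side group is not as indifferent to change as the bromo step suggested, since the first two compounds could not be told apart. Changing 4-bromobenzyl to 2-(trifluoromethyl)benzyl gives a 6.2-fold higher number from compound 2 to compound 3 (0.80 log units; beyond the scatter), and adding trifluoromethyl to the unsubstituted benzyl gives a 5.0-fold higher number from compound 1 to compound 3 (0.70 log units; beyond the scatter). On this read-out a higher number stands for weaker inhibition, so compound 3 is the weakest of the three, and both steps, starting from either neighbour, point the same way: this ring can carry a 4-bromo group without a readable change, but the 2-(trifluoromethyl) pattern costs activity.

The change from compound 2 to compound 3 alters both the group and where it sits on the ring, so these compounds leave open whether the loss belongs to trifluoromethyl itself or to its place, a question that 4-(trifluoromethyl)benzyl and 2-bromobenzyl would help to separate. Nothing available here explains the loss of activity.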